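The source may hold more compounds than are shown below. What is called first, only, known or untested is meant among the compounds shown, and "the series" means these compounds.

Three analogues sharing one core have been measured. Compound 1 `C#CCSc1nc(Nc2ccc(OC)cc2)c(C#N)c(-c2ccccc2)n1` gives 28400 nM in a functional assay on MGC-803 cells (Homo sapiens) for inhibition, read by MTT assay, with a stated time of 72 h; on this read-out higher numbers stand for weaker inhibition and lower numbers for stronger inhibition. Compound 2 `C#CCSc1nc(Nc2ccccc2Cl)c(C#N)c(-c2ccccc2)n1` gives 52800 nM in this assay, the highest of the two plain numbers, although the step of a 1.9-fold higher number from compound 1 to compound 2 (0.27 log units; within the scatter) lies within the scatter. Compound 3 `C#CCSc1nc(Nc2ccc(Cl)cc2)c(C#N)c(-c2ccccc2)n1` reaches only a limit of this assay, > 128000 nM. The step of an at least 2.4-fold higher number from compound 2 to compound 3 (0.38 log units; beyond the scatter) is at least modest, and so is the step of an at least 4.5-fold higher number from compound 1 to compound 3 (0.65 log units; beyond the scatter).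

Compound 4 `C#CCSc1nc(Nc2cccc(Cl)c2)c(C#N)c(-c2ccccc2)n1` has not yet been measured. It differs from compound 2 by 3-chlorophenyl in place of 2-chlorophenyl on a nitrogen on an aromatic ring. For the measured compounds named here, two measured steps bear on this change: the step from compound 2 to compound 3, which moved the chloro group on the same ring and was at least modest, and the step from compound 1 to compound 2, which stayed within the scatter. A modest rise in this assay is therefore expected, a 1.5-fold higher number from compound 2 to compound 4 (0.18 log units; within the scatter). The limit of > 128000 nM in this assay, at which 1 of the 3 values shown sits, reached by compound 3 shows that a limit rather than a number is also possible. Compound 4 is estimated to give about 80000 nM, between 35000 nM and 200000 nM.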

Compound 4, half-maximal inhibitory concentration: > 128000 nM
Compound 4: no number, only a limit; the forecaster's own chance of this, stated with the estimate: 35%; middle value at least 1.6-fold (0.20 log units) from the limit.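

In this assay compound 4 gives only a limit, > 128000 nM. Moving the chloro group from the 2-chlorophenyl to the 3-chlorophenyl form produces an at least 2.4-fold higher number from compound 2 to compound 4 (0.38 log units; beyond the scatter), and 3-chlorophenyl in place of 4-methoxyphenyl produces an at least 4.5-fold higher number from compound 1 to compound 4 (0.65 log units; beyond the scatter), so among the chlorophenyl compounds shown, only the 2-chlorophenyl one keeps a plain number. Compound 3 and compound 4 now share one limit, and the step between them cannot be read: the limit of > 128000 nM in this assay, at which 2 of the 4 values shown sit.

Going by these compounds, how far either compound lies past that limit stays open, so the 3-chlorophenyl and 4-chlorophenyl groups cannot be put in any order. Also open, on these data alone, is whether a 3-methoxyphenyl group, or an aniline ring carrying an amine or a carboxylic acid, would give a plain number in this assay.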